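Adding an amino group to compound 2

This account rests on a few compounds, and the source may have more. Where it says the series, first, only, none or still open, it means among the compounds named here.

Values in a functional assay on MCF7 cells (Homo sapiens) for cytotoxicity, read by sulforhodamine B assay, with a stated time of 48 h; a lower number here means that less compound is tolerated, a higher number that more compound is tolerated:
Compound 1 `ClCc1ccccc1Cn1cnc2c(Cl)nc(Cl)nc21`: > 100000 nM
Compound 2 `ClCc1ccccc1Cn1cnc2c(Cl)ncnc21`: > 100000 nM
Compound 3 `ClCc1cccc(Cn2cnc3nc(Cl)nc(Cl)c32)c1`: > 100000 nM

Each of these three values is a limit of the measurement rather than a number: the cells tolerated the highest concentration tested. Compound 2 therefore stands at the limit of > 100000 nM in this assay, at which 3 of the 3 values shown sit, and the other two compounds stand at the same limit, so no measured number exists in this set. For the measured compounds named here, the only step between two measured compounds that differ in a single place is a step that the two limits leave unreadable from compound 1 to compound 2, and the two limits leave its size unreadable.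

Compound 4 `Nc1nc(Cl)c2ncn(Cc3ccccc3CCl)c2n1` is the compound to be measured next. Its difference from compound 2 is amino in place of hydrogen on an aromatic carbon; the new group sits between two ring nitrogen atoms, meta to a chloro group. Going by the values given here, no measured step involves an amino group, so the expectation rests only on where compound 2 stands and on the fact that all three measured compounds sit at the limit. Compound 4 is expected to remain at that limit as well. The expected step is a number no higher from compound 2 to compound 4 (the limit leaves the size open), meaning no change beyond the scatter. Compound 4 is accordingly estimated at 100000 nM, within a range from 30000 nM to 300000 nM.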

Compound 4, concentration lethal to 50% of the cells: 87100 nM
Compound 4: the middle estimate sits 1.1-fold (0.06 log units) above what was measured; low and high end bracket the measured number.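

In this assay, for the compounds shown here, compound 4 gives 87100 nM, the first reading in this set that is a number and not a limit, so an amino group on this aromatic carbon, between two ring nitrogen atoms, leaves a compound whose effect on the cells can be measured. From the compounds shown here alone, replacing hydrogen with amino gives an at least 1.1-fold lower number from compound 2 to compound 4 (0.05 log units; that floor lies within the scatter), and replacing chloro with amino at the same position gives an at least 1.1-fold lower number from compound 1 to compound 4 (0.05 log units; that floor lies within the scatter), so neither step can be called a real change: each is only a floor, and the true size stays unknown. The number for compound 4 therefore sits close to the top of the tested range, and the only comparison available is with compounds that stop at that limit: the limit of > 100000 nM in this assay, at which 3 of the 4 values shown sit.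

Going by these compounds, whether a methylamino or hydroxyl group at this position would give a number clearly lower than that of compound 4 remains open. On these data alone, it is also open whether a methoxy group in place of the remaining chloro group would alter the reading, and whether an amino group would give a number on compound 3.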